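Swapping Ureido for Hydroxy on the Higher-Scoring Compound

A few compounds are considered here, and "the series" means these few. Any claim that something is new, unique, unknown or untested is made for them only; others in the source may bear on it.

In a functional assay on PC-3 cells (Homo sapiens) for inhibition, read by sulforhodamine B assay, with a stated time of 48 h, tested at 50 uM (a lower number here means less inhibition of growth, a higher number more inhibition of growth at the concentration tested), compound 1 `COc1ccc([C@@H]2C/C(=N/OCc3cn(-c4cccc(CO)c4)nn3)c3cc(CC=C(C)C)c(OC)cc3O2)cc1` gives 34%. Compound 2 `COc1cc2c(cc1CC=C(C)C)/C(=N/NC(N)=O)C[C@@H](c1ccc(O)cc1)O2` gives 67%, the higher of the two numbers, and the gap between them lies beyond the usual scatter of repeated measurements. These two compounds differ in more than one place, so their gap does not show what any single change does. Compound 3 `COc1cc2c(cc1CC=C(C)C)/C(=N/O)C[C@@H](c1ccc(O)cc1)O2` departs from compound 2 in one place, with hydroxy in place of ureido on a double-bonded nitrogen. No measured single change is available as a guide, so this forecast is uncertain. A modest fall in this assay is expected, of a size close to the scatter, and the estimated change is a number 10 percentage points lower from compound 2 to compound 3 (within the scatter). Compound 3 is expected to give 57%, with an estimated range from 35% to 78%.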

Compound 3, percent growth inhibition at one concentration: 81%
For compound 3 the middle estimate is 24 percentage points below the measured one; measured number above the stated range.
By their numbers in this assay, from the lowest: compound 1; then compound 2; then compound 3.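

Putting hydroxy in place of ureido on a double-bonded nitrogen gives a number 14 percentage points higher from compound 2 to compound 3 (beyond the scatter) in this assay, so the larger ureido group is not needed at this position for growth inhibition in this pair. Here the smaller group gives the higher reading, something the gap between compound 1 and compound 2 could not show, as those compounds differ in more than one place. No measured information accounts for this rise.

This single pair cannot show whether the rise comes from the presence of hydroxy or simply from the loss of ureido. An amine on the same nitrogen, or a short carbon chain joined through the oxygen of compound 3, would show how much this position tolerates and help separate those two readings.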